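The source may hold more compounds than are shown below. What is called first, only, known or untested is meant among the compounds shown, and "the series" means these compounds.

Of the compounds shown here, three have been tested so far in a functional assay on MOLT-4 cells (Homo sapiens) for inhibition; on this read-out higher numbers stand for weaker inhibition and lower numbers for stronger inhibition. Compound 1 `Cc1cccc(/C=C2\Cc3ccccc3C2=O)c1` gives 80300 nM, and compound 2 `CN(C)c1ccc(/C=C2\CCc3ccccc3C2=O)cc1` gives 2110 nM. Compound 3 `O=C1CCCCC/C1=C\c1cccc(Br)c1` gives 176000 nM, the highest number of the three and so the weakest inhibition, with its gaps to both others beyond the usual scatter of repeat measurements. Compound 4 `O=C1CCCCC/C1=C\c1cccc([N+](=O)[O-])c1` differs from compound 3 in one place, with nitro in place of bromo on an aromatic carbon. Going by the values given here, no two tested compounds differ in only one place, so the data offer no direct guide to this swap. In this assay, only a small step toward stronger inhibition is expected, probably not beyond the scatter. The slight lean rests on position alone: compound 3, at 176000 nM, already stands at the top of the values seen. For compound 4, the estimated value is 110000 nM, with an expected range from 35000 nM to 300000 nM. This estimate amounts to an expected step of a 1.6-fold lower number from compound 3 to compound 4 (0.20 log units; within the scatter).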

Compound 4, half-maximal inhibitory concentration: 39200 nM
Beside the measured number, compound 4's estimate is 2.8-fold (0.45 log units) above it, within the range that was stated.
By their numbers in this assay, from the lowest: compound 2; then compound 4; then compound 1; then compound 3.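

Going by these compounds alone, this is the first pair in this assay that differs in only one place, so a single swap can now be read directly: nitro in place of bromo on an aromatic carbon gives a lower number and so stronger inhibition (a 4.5-fold lower number from compound 3 to compound 4 (0.65 log units; beyond the scatter)). The position therefore responds to the group it carries. Here the step is modest but lies beyond the usual scatter of repeat measurements. Nothing in the available data accounts for this gain.

The compounds shown leave open how other groups at this place, such as a carboxylic acid or a nitrile, would compare with nitro and bromo. They also leave open whether the same swap would give a step of similar size on the core of compound 1 or compound 2.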